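Dropping an Amino Group: From Compound 3 to Compound 4

This account rests on a few compounds, and the source may have more. Where it says the series, first, only, none or still open, it means among the compounds named here.

Measured so far:
- compound 1, `COc1ccc(/C=C/C(=O)c2cccc(-c3cccc(F)c3)c2)cc1`: a limit, > 50000 nM
- compound 2, `Nc1ccc(C(=O)/C=C/c2ccc(O)c(F)c2)cc1-c1ccc(F)cc1`: a limit, > 50000 nM
- compound 3, `COc1ccc(/C=C/C(=O)c2ccc(N)c(-c3ccc(F)cc3)c2)cc1OC`: a limit, > 50000 nM

All three compounds were tested in an assay on A549 cells for inhibition of transcription factor p65 (Homo sapiens), read by fluorescence, with a stated time of 2 h; on this read-out lower numbers stand for stronger inhibition and higher numbers for weaker inhibition. None of them gave a number: each value is a limit of the assay. Compound 3 therefore stands at the limit, and so do the two other compounds, as the limit of > 50000 nM in this assay, at which 3 of the 3 values shown sit, shows. Among the measured compounds shown here, no pair of measured compounds differs in one place only, so no measured step is available to judge from.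

Compound 4, `COc1ccc(/C=C/C(=O)c2cccc(-c3ccc(F)cc3)c2)cc1OC`, has not yet been measured in this assay. It differs from compound 3 by hydrogen in place of amino on an aromatic carbon. With compound 3 sitting at the limit, and with every other measured compound sitting there too, there is no sign in these data that a small change of this kind moves a compound into the range where a number appears. The step that the limit leaves unreadable from compound 3 to compound 4 is expected to be none beyond the scatter. Compound 4 is estimated at 80000 nM, with a range from 30000 nM to 300000 nM, most probably reported once more as a limit.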

Compound 4, half-maximal inhibitory concentration: > 50000 nM
Compound 4: no number, only a limit; the forecaster's own chance of this, stated with the estimate: 85%; the middle value lies beyond the limit too.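

Compound 3 and compound 4 each give only a limit rather than a number, so the step between them cannot be read. The compounds shown leave open whether swapping amino for hydrogen changes anything, and which structure, if any, would give a real number.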